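The source may hold more compounds than are shown below. What is called first, only, known or untested is meant among the compounds shown, and "the series" means these compounds.

Compound 1 `Cc1nc(N2CCCC2)c2nnn(-c3ccc(C(C)C)cc3Br)c2n1`: 194 nM
Compound 2 `CCCCN(CCCC)c1nc(C)nc2c1ncn2-c1ccc(C(C)C)cc1Br`: 6.1 nM
Compound 3 `CCCCN(CC)c1nc(C)nc2c1ncn2-c1c(Cl)cc(OC)cc1OC`: 5.2 nM

In an in vitro assay on 293-EBNA cells for binding affinity to corticotropin-releasing factor receptor 1 (Homo sapiens) (on this read-out higher numbers stand for weaker inhibition and lower numbers for stronger inhibition), compound 1 gives 194 nM, the highest number of the three; compound 2 gives 6.1 nM and compound 3 gives 5.2 nM, both lower by margins beyond the usual scatter, so compound 1 is the weakest binder shown.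

Compound 4 `CCOCC(COCC)Oc1nc(C)nc2c1nnn2-c1ccc(C(C)C)cc1Br` differs from compound 1 in one place: a group of 10 heavy atoms (7 carbon, 3 oxygen; no ring) in place of a group of 5 heavy atoms (4 carbon, 1 nitrogen; one five-membered non-aromatic ring with 1 hetero atom), on an aromatic carbon. Going by the values given here, no measured pair tracks this exact change. Where compound 1 has the pyrrolidin-1-yl, compound 2 carries a larger group without a ring, and compound 2 gives 6.1 nM, which suggests that a larger, open-chain group can go with a lower number. A sizable step toward stronger binding is therefore expected, a 6.5-fold lower number from compound 1 to compound 4 (0.81 log units; beyond the scatter), beyond the scatter. Compound 4 is estimated at 30 nM, in a range from 5 nM to 150 nM.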

Compound 4, inhibition constant: 39.7 nM
Compound 4: middle estimate off by 1.3-fold (0.12 log units), on the low side, and the stated range covers the measured number.
By their numbers in this assay, from the lowest: compounds 3 and 2 (each within the scatter of the next); then compound 4; then compound 1.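

In this assay, the pyrrolidin-1-yl on this aromatic carbon can be replaced by a larger open-chain group of 10 heavy atoms, and this gives a 4.9-fold lower number from compound 1 to compound 4 (0.69 log units; beyond the scatter). So on this core, binding at this position does not depend on the ring, and the position tolerates a group with oxygen atoms in place of the ring nitrogen. Nothing measured here explains the step. Going by these compounds, what remains open is whether losing the ring, gaining the oxygens or adding size matters most. A diethylamino group at this position would help separate these changes.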